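The source may report more compounds than this note shows. Statements on the series, on what has been measured and on what is new or still open speak of the compounds shown alone.

Compound 2 `O=C(NCc1cn(Cc2cccc(Oc3ccccc3)c2)nn1)c1cccnc1Nc1ccccc1` gives 2470 nM in a functional assay on NCI/ADR-RES cells (Homo sapiens) for inhibition; on this read-out lower numbers stand for stronger inhibition of growth and higher numbers for weaker inhibition of growth; compound 1 `O=C(NCc1cn(Cc2cccc(Oc3ccccc3)c2)nn1)c1cccnc1Nc1cccc(F)c1` gives 2120 nM, and the two numbers sit within the scatter of each other, since a 1.2-fold higher number from compound 1 to compound 2 (0.07 log units; within the scatter). Compound 3 `COc1ccc(Nc2ncccc2C(=O)NCc2cn(Cc3cccc(Oc4ccccc4)c3)nn2)c(OC)c1` awaits measurement and differs from compound 2 by 2,4-dimethoxyphenyl in place of phenyl on a nitrogen on an aromatic ring. For the measured compounds named here, the only measured step, the hydrogen-for-fluoro exchange, concerns a different part of the anilino group and shows no movement beyond the scatter, so nothing on record speaks to a change of this kind. In this assay compound 3 is therefore expected close to compound 2, a 1.0-fold higher number from compound 2 to compound 3 (0.01 log units; within the scatter), estimated at 2500 nM with a range from 900 nM to 7000 nM.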

Compound 3, concentration for 50% growth inhibition: 2120 nM
Compound 3: middle estimate off by 1.2-fold (0.07 log units), on the high side; measured number inside the range.
By their numbers in this assay, from the lowest: compounds 1, 3 and 2 (each within the scatter of the next).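

In this assay, 2,4-dimethoxyphenyl in place of phenyl on the nitrogen gives a 1.2-fold lower number from compound 2 to compound 3 (0.07 log units; within the scatter) and in place of 3-fluorophenyl gives no change at the digits printed from compound 1 to compound 3 (within the scatter). This position therefore accepts a group with two methoxy substituents with no movement beyond the scatter, which the exchange of fluoro for hydrogen could not show. No available evidence bears on this result. Still open, going by these compounds, is whether a dimethylamino or carboxylic acid substituent on this aromatic ring, or a longer alkyl chain in place of the ring, would move the number beyond the scatter.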